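Dimethylcarbamoyl in place of pyrrolidinylcarbonyl: series notes

A few compounds are considered here, and "the series" means these few. Any claim that something is new, unique, unknown or untested is made for them only; others in the source may bear on it.

Measured compounds:
Compound 1 `O=C(/C=C/CNCCOc1ccc(Oc2c(-c3ccc(F)cc3)sc3cc(O)ccc23)cc1)N1CCCCC1`. In a functional assay on MDA-MB-231 cells (Homo sapiens) for antiproliferative activity, read by CCK-8 assay, with a stated time of 48 h (a lower number here means a stronger inhibitor, a higher number a weaker inhibitor), compound 1 gives > 50000 nM, which is a limit of the assay.
Compound 2 `O=C(/C=C/CN1CC(Oc2ccc(Oc3c(-c4ccc(F)cc4)sc4cc(O)ccc34)cc2)C1)N1CCCC1`. In this assay compound 2 gives > 50000 nM, also a limit.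
Compound 3 `O=C(/C=C/CNCCOc1ccc(Oc2c(-c3ccc(F)cc3)sc3cc(O)ccc23)cc1)N1CCCC1`. In this assay compound 3 gives > 50000 nM, again a limit.

Compound 2 thus stands only at a limit, as do the other two values, all three sitting at the limit of > 50000 nM in this assay, at which 3 of the 3 values shown sit. For the measured compounds named here, the one measured step, a step that the two limits leave unreadable from compound 1 to compound 3, has both ends at limits and so cannot be read. Compound 4 `CN(C)C(=O)/C=C/CN1CC(Oc2ccc(Oc3c(-c4ccc(F)cc4)sc4cc(O)ccc34)cc2)C1` differs from compound 2 by dimethylamino in place of pyrrolidin-1-yl on a carbonyl carbon. Going by the values given here, no measured step bears on this change; the sole comparison among the measured compounds is unreadable, so neither size nor direction can be drawn from the numbers. The expectation for compound 4 in this assay is a step that the limit leaves unreadable from compound 2 to compound 4, an estimate resting only on (the limit of > 50000 nM in this assay, at which 3 of the 3 values shown sit). Compound 4 is therefore expected near 60000 nM, within 20000 nM to 200000 nM, most likely reported as a limit once more.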

Compound 4, half-maximal inhibitory concentration: > 50000 nM
Compound 4 ended at the assay's limit (the forecaster's own chance of this, stated with the estimate: 85%); the middle value lies beyond the limit too.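

Compound 2 and compound 4 both sit at a limit in this assay, so the step between them cannot be read: the limit of > 50000 nM in this assay, at which 4 of the 4 values shown sit.

The compounds shown leave open what effect, in size or direction, any of these changes has in this assay.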